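Replacing a linker methylene with a methyl-bearing aryl ring

The source may hold more compounds than are shown below. What is called first, only, known or untested is meant among the compounds shown, and "the series" means these compounds.

Of the compounds shown here, three have been measured in an assay on HEK293 cells for positive allosteric modulation of metabotropic glutamate receptor 3 (Rattus norvegicus), read by thallium flux, with a stated time of 2.5 min; a higher number here means that more compound is needed for the effect, a lower number that less compound is needed. Compound 1 `Cc1cc(C(=O)O)ccc1OCCCCOc1ccc(C(=O)CC(C)C)c(O)c1C` gives 1850 nM, compound 2 `Cc1c(OCCCCOCOc2ccc(C(=O)O)cc2)ccc(C(=O)CC2CCCC2)c1O` gives 1910 nM, and compound 3 `COc1ccc(C(=O)O)cc1OCCCCOc1ccc(C(=O)CC(C)C)c(O)c1C` gives 737 nM. Compound 2 has the highest number of the three; compound 1 sits within the scatter of it, while compound 3 lies beyond the scatter, at a lower number.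

Compound 4 `Cc1cc(OCCCCOc2ccc(C(=O)CC3CCCC3)c(O)c2C)ccc1C(=O)O` has not yet been measured. It differs from compound 2 in one place: 4-carboxy-3-methylphenyl in place of (4-carboxyphenoxy)methyl on an oxygen on a saturated carbon. Compound 4 shares with compound 1 the 4-carboxy-3-methylphenyl group and the four-carbon chain, and with compound 2 the cyclopentyl-bearing ketone.

No measured pair shows this exact change, so the step can only be guessed from what is shown. Compound 1 with 1850 nM and compound 2 with 1910 nM lie within the scatter of each other, so compound 4 is expected to land close to both, with a step of a 1.1-fold lower number from compound 2 to compound 4 (0.05 log units; within the scatter) that stays within the scatter. Compound 4 is therefore estimated at 1700 nM, with a range from 700 nM to 4000 nM.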

Compound 4, half-maximal effective concentration: > 10000 nM
Compound 4 ended at the assay's limit (the forecaster's own chance of this, stated with the estimate: 10%); middle value at least 5.8-fold (0.76 log units) from the limit.
By their numbers in this assay, from the lowest: compound 3; then compounds 1 and 2 (each within the scatter of the next). At a limit, above all of these: compound 4.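

In this assay compound 4 reads > 10000 nM, which is a limit of the assay and not a number. Going by these compounds alone, this gives the first reading of a single change: with the cyclopentyl-bearing ketone kept, putting 4-carboxy-3-methylphenyl in place of (4-carboxyphenoxy)methyl gives an at least 5.2-fold higher number from compound 2 to compound 4 (0.71 log units; beyond the scatter), so this position is sensitive to what sits on the oxygen, even though both groups carry a carboxylic acid on an aromatic ring. The true size of the step remains unknown, and the figure printed for it is only a minimum: the limit of > 10000 nM in this assay, at which 1 of the 4 values shown sits.

The compounds shown leave open whether the step comes from the added methyl group or from the loss of the oxygen and carbon that link the ring in compound 2. A plain 4-carboxyphenyl group on the same oxygen would help to separate these two changes.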